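Working notes on compound 4 and a second fluoro

The compounds below may be only part of what the source reports. "The series", "measured", "known", "first", "only" and "open" are said of these compounds alone.

Measured so far:
- compound 1 `C(=N/Nc1nc(-c2ccccc2)cs1)\c1ccc(N2CCCC2)cc1`: > 1000000 nM (a limit)
- compound 2 `N#Cc1ccc(-c2csc(N/N=C/c3ccc(N4CCCC4)cc3)n2)cc1`: 53100 nM
- compound 3 `Fc1ccc(-c2csc(N/N=C/c3ccc(N4CCCC4)cc3)n2)cc1`: 426000 nM

In an assay on isolated protein for inhibition of Amine oxidase [flavin-containing] B (Homo sapiens), read by fluorescence and Amplex Red, with a stated time of 30 min (on this read-out higher numbers stand for weaker inhibition and lower numbers for stronger inhibition), compound 1 reaches only the limit > 1000000 nM (the limit of > 1000000 nM in this assay, at which 1 of the 3 values shown sits). Compound 2 gives 53100 nM, and compound 3 gives 426000 nM, the highest of the two numbers shown; the gap is an 8.0-fold higher number from compound 2 to compound 3 (0.90 log units; beyond the scatter). Compound 4 `Fc1ccc(-c2csc(N/N=C/c3ccc(N4CCCC4)cc3)n2)c(F)c1` differs from compound 3 by fluoro in place of hydrogen on an aromatic carbon. The nearest measured change on this ring is an at least 2.3-fold lower number from compound 1 to compound 3 (0.37 log units; beyond the scatter), read against a limit, while an at least 18-fold lower number from compound 1 to compound 2 (1.27 log units; beyond the scatter) shows that a cyano at the first position did more than a fluoro. A second fluoro is expected to move the number less than the first did, with an expected step of a 1.7-fold lower number from compound 3 to compound 4 (0.23 log units; within the scatter). Compound 4 is therefore estimated at 250000 nM, with a range from 80000 nM to 800000 nM.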

Compound 4, half-maximal inhibitory concentration: 141000 nM
Estimate against measurement, compound 4: 1.8-fold (0.25 log units) above, within the range that was stated.
By their numbers in this assay, from the lowest: compound 2; then compound 4; then compound 3. At a limit, above all of these: compound 1.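

With one fluoro already on the ring, a second on the aromatic carbon ortho to a large group still counts: the series shows a 3.0-fold lower number from compound 3 to compound 4 (0.48 log units; beyond the scatter) and so this place responds to fluoro. The 2,4-difluorophenyl stays behind the 4-cyanophenyl, with a 2.7-fold higher number from compound 2 to compound 4 (0.42 log units; beyond the scatter) as the gap. Against phenyl the reading is an at least 7.0-fold lower number from compound 1 to compound 4 (0.85 log units; beyond the scatter) as a bound only, since compound 1 stands at a limit: the limit of > 1000000 nM in this assay, at which 1 of the 4 values shown sits.

Still open, going by these compounds, is whether a group larger than fluoro at this place, such as methoxy or an amine, keeps the gain. Also open, on these data alone, is whether a nitrile and this fluoro together go beyond either alone.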